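Swapping the Aryl Amide Tail on a Long-Chain Binder

A few compounds are considered here, and "the series" means these few. Any claim that something is new, unique, unknown or untested is made for them only; others in the source may bear on it.

Measured compounds:
- compound 1, `Cn1c(Cc2nn(C)c(=O)c3ccccc23)nnc1SCCCCCCCCCCC(=O)Nc1ccc(Cl)cc1Cl`: "not determined" (no result reported)
- compound 2, `Cn1c(Cc2nn(C)c(=O)c3ccccc23)nnc1SCCCCCCCC(=O)Nc1ccc(Br)cc1Br`: 11600 nM
- compound 3, `Cn1c(Cc2nn(C)c(=O)c3ccccc23)nnc1SCCCCCCCC(=O)Nc1ccc(F)cc1F`: "not determined" (no result reported)

These three compounds share one core and differ only in the group carried on the amide nitrogen at the far end of a long chain. In an assay on isolated protein for binding affinity to interleukin-15 (Homo sapiens), read by surface plasmon resonance (on this read-out lower numbers stand for tighter binding and higher numbers for weaker binding), compound 2 gives 11600 nM. For the measured compounds named here, compound 1 gives "not determined" (no result reported), and compound 3 likewise gives "not determined" (no result reported), so compound 3 stands without a number of its own; the only measured value in this small set is that of compound 2.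

Compound 4, `Cc1ccc(NC(=O)CCCCCCCSc2nnc(Cc3nn(C)c(=O)c4ccccc34)n2C)c(Cl)c1`, is the next member. It differs from compound 3 by 2-chloro-4-methylphenyl in place of 2,4-difluorophenyl on an amide-type nitrogen. Going by the values given here, with no number for compound 3, there is no measured step to lean on, and the one available value, that of compound 2, lies in the weak range. The expectation for compound 4 in this assay is therefore weak binding of a similar order, with no reason to foresee a change beyond the scatter in either direction. Compound 4 is estimated at 12000 nM, in the range 3000 nM to 50000 nM.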

Compound 4, dissociation constant: 24100 nM
Estimate against measurement, compound 4: 2.0-fold (0.30 log units) below; the measured number falls inside the stated range.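

In this assay, replacing 2,4-dibromophenyl with 2-chloro-4-methylphenyl on the amide-type nitrogen gives a 2.1-fold higher number from compound 2 to compound 4 (0.32 log units; beyond the scatter) and so provides the first measured sign that binding responds to the aryl group at this position. For the compounds shown here, the change is modest, and it shows only that these two groups can be told apart, not which feature of them matters. Compound 3 has no single number, so the steps that involve it cannot be read, and no measurement here explains the shift.

Open, from the compounds shown here alone, is how binding would respond to a wider change at this position, such as a plain phenyl or a phenyl carrying an amine or a carboxylic acid. Also open, going by these compounds, is whether a longer chain changes binding, since compound 1 has no number to compare.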